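This account rests on a few compounds, and the source may have more. Where it says the series, first, only, none or still open, it means among the compounds named here.

Compound 1 `c1ccc(C(CCN/C2=N/CCCCCN2)c2ccccc2)cc1` and compound 2 `CN1CCCN=C1NCCC(c1ccccc1)c1ccccc1` share a core in which a chain ends at an amine nitrogen, and they differ only in the ring attached to that nitrogen. In an assay on cell membranes with Voltage-dependent L-type calcium channel subunit alpha-1C (Rattus norvegicus) as the target (a lower number here means a stronger inhibitor, a higher number a weaker inhibitor), compound 1 gives > 1000 nM, which is a limit and not a number. In this assay compound 2 likewise gives > 1000 nM, again a limit. The step from compound 1 to compound 2 is a step that the two limits leave unreadable from compound 1 to compound 2, so no size can be read from it. Both values sit at the limit of > 1000 nM in this assay, at which 2 of the 2 values shown sit. Compound 3 `CN1CCN=C1NCCC(c1ccccc1)c1ccccc1` differs from compound 2 by a group of 6 heavy atoms (4 carbon, 2 nitrogen; one five-membered non-aromatic ring with 2 hetero atoms) in place of a group of 7 heavy atoms (5 carbon, 2 nitrogen; one six-membered non-aromatic ring with 2 hetero atoms), on an amine nitrogen. No measured step bears on this change, since the one step shown is unreadable, and nothing points toward stronger binding. Compound 3 is therefore expected to stay weak, with an estimated value of 3000 nM within 800 nM to 20000 nM. The expected step from compound 2 to compound 3 is a step that the limit leaves unreadable from compound 2 to compound 3, not resolvable beyond the scatter.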

Compound 3, half-maximal inhibitory concentration: > 1000 nM
Compound 3: no number, only a limit; the forecaster's own chance of this, stated with the estimate: 80%; the middle value lies beyond the limit too.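

No step can be read among compound 1, compound 2 and compound 3, since all three results are limits and not numbers: the limit of > 1000 nM in this assay, at which 3 of the 3 values shown sit. The compounds shown leave open how strongly each binds in this assay, and whether changing the ring on the amine nitrogen alters that binding at all.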